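Replacing cyano with 2-cyanoethyl in compound 3

The source may report more compounds than this note shows. Statements on the series, on what has been measured and on what is new or still open speak of the compounds shown alone.

Values in an ADME assay on MT2 cells (Homo sapiens) for cytotoxicity (on this read-out lower numbers stand for higher toxicity in this test and higher numbers for lower toxicity in this test), so far:
Compound 1 `Cc1cc(C#N)cc(C)c1Oc1cc(Nc2ccc(C#N)cc2)c(N)cc1CNC1CC1` gives 12100 nM
Compound 2 `Cc1cc(C#N)cc(C)c1Oc1cc(Nc2ccc(C#N)cc2)c(N)cc1CNCCCO` gives 15100 nM
Compound 3 `COCc1cc(N)c(Nc2ccc(C#N)cc2)cc1Oc1c(C)cc(C#N)cc1C` gives 146000 nM

Compound 3 stands highest of the three at 146000 nM on this read-out. Among the compounds with values here, compound 4 `COCc1cc(N)c(Nc2ccc(C#N)cc2)cc1Oc1c(C)cc(CCC#N)cc1C` carries 2-cyanoethyl in place of cyano on an aromatic carbon and no measured step touches that place. The measured steps bear on it only loosely: a 12-fold higher number from compound 1 to compound 3 (1.08 log units; beyond the scatter) and a 9.7-fold higher number from compound 2 to compound 3 (0.99 log units; beyond the scatter) came from changes on a saturated chain carbon and a 1.2-fold higher number from compound 1 to compound 2 (0.10 log units; within the scatter) from a change on an amine nitrogen. They give no direction here. With compound 3 at 146000 nM already the top of the three, a moderate drop is expected in this assay rather than a further rise. The expected step is a 2.4-fold lower number from compound 3 to compound 4 (0.39 log units; beyond the scatter) and no more than that. Compound 4 is estimated at 60000 nM with 15000 nM to 180000 nM as the expected range.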

Compound 4, half-maximal cytotoxic concentration: > 200000 nM
Compound 4 gave a limit, no number; the forecaster's own chance of this, stated with the estimate: 15%; middle value at least 3.3-fold (0.52 log units) from the limit.
By their numbers in this assay, from the lowest: compounds 1 and 2 (each within the scatter of the next); then compound 3. At a limit, above all of these: compound 4.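

Within the data shown here, compounds 1 to 3 all carry cyano at this place, so compound 4 gives the first reading of a change on this aromatic carbon, meta to two methyl groups. In this assay compound 4 gives > 200000 nM, which is a limit of the read-out and not a number: the limit of > 200000 nM in this assay, at which 1 of the 4 values shown sits. With 2-cyanoethyl in place of cyano, the result is an at least 1.3-fold higher number from compound 3 to compound 4 (0.13 log units; that floor lies within the scatter), so no fall appears, while the floor alone does not establish a rise.

As far as these compounds go, how far compound 4 lies past its limit remains open. So does what a longer chain or a carboxylic acid at this place would give.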